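Swapping fluoro for trifluoromethyl in a weak cytotoxic compound

A few compounds are considered here, and "the series" means these few. Any claim that something is new, unique, unknown or untested is made for them only; others in the source may bear on it.

Compound 1 `Cc1ccc(S(=O)(=O)N2C/C(=C\c3ccncc3)C(=O)/C(=C/c3ccccc3F)C2)cc1`: > 20000 nM
Compound 2 `O=C1/C(=C/c2ccncc2)CN(S(=O)(=O)c2ccc(Br)cc2)C/C1=C\c1ccccc1F`: 11500 nM

Both compounds were tested in a functional assay on QGY-7703 cells (Homo sapiens) for cytotoxicity, read by MTT assay, with a stated time of 24 h; on this read-out higher numbers stand for weaker inhibition and lower numbers for stronger inhibition. Compound 1 stands at the limit of > 20000 nM in this assay, at which 1 of the 2 values shown sits, so its value is a limit and not a number. Within the data shown here, compound 2 gives the only exact number so far.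

The next compound to consider is compound 3 `Cc1ccc(S(=O)(=O)N2C/C(=C\c3ccncc3)C(=O)/C(=C/c3ccccc3C(F)(F)F)C2)cc1`. It keeps the core of compound 1 but has trifluoromethyl in place of fluoro on an aromatic carbon. The new group sits on a six-membered aromatic ring of carbon only, ortho to a large group.

Among the measured compounds shown here, the one measured step is an at least 1.7-fold lower number from compound 1 to compound 2 (0.24 log units; that floor lies within the scatter). It is a bromo in place of methyl on an aromatic carbon, at a different place in the molecule, so it bears on the new change only indirectly. For the measured compounds named here, no measured step shows what happens at the fluoro position. Any step in this assay is therefore expected to stay within the scatter, in neither direction. This expectation leans on compound 2 at 11500 nM as the only numerical anchor.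

The estimated step is an at least 1.1-fold lower number from compound 1 to compound 3 (0.07 log units; that floor lies within the scatter).

For compound 3 the expected value is 17000 nM, with an estimated range from 7000 nM to 40000 nM.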

Compound 3, half-maximal inhibitory concentration: 5090 nM
Beside the measured number, compound 3's estimate is 3.3-fold (0.52 log units) above it, outside the stated range (below it).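

In this assay, the change from 2-fluorophenyl to 2-(trifluoromethyl)phenyl gives an at least 3.9-fold lower number from compound 1 to compound 3 (0.59 log units; beyond the scatter). Among these compounds, this is the first measured change at this position, and it shows that changing the group here can shift the read-out by more than the usual scatter, whereas the earlier step elsewhere in the molecule, an at least 1.7-fold lower number from compound 1 to compound 2 (0.24 log units; that floor lies within the scatter), did not establish a change of that kind. The true size of the new step remains uncertain, since the starting point is a limit and not a number, so the printed step is only a floor: the limit of > 20000 nM in this assay, at which 1 of the 3 values shown sits.

On these data alone, whether a chloro, methoxy or nitrile group at this place would also lower the number remains open, as does whether the same change would have a similar effect on compound 2, which carries bromo in place of methyl. The step replaces 1 heavy atom with 4 heavy atoms, and the compounds shown cannot tell whether the lower number goes with the added atoms, with the kind of group, or with both.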